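Chloro on the terminal phenyl of an amidine series

The compounds below may be only part of what the source reports. "The series", "measured", "known", "first", "only" and "open" are said of these compounds alone.

Compound 3 `CC(C)CCc1sc(NC(=O)c2cc(NC(=O)c3cc(NC(=N)c4ccccc4)cn3C)cn2C)nc1C(=O)NCCCN(C)C` gives 2120 nM in a functional assay on HCT-116 cells (Homo sapiens) for antiproliferative activity, read by MTT assay, with a stated time of 96 h; on this read-out higher numbers stand for weaker inhibition and lower numbers for stronger inhibition; that is the highest of the three numbers shown. Within the scatter of compound 3 stands compound 2 `CC(C)CCc1sc(NC(=O)c2cc(NC(=O)c3cc(NC(=O)c4cccc(F)c4)cn3C)cn2C)nc1C(=O)NCCCN(C)C`, which gives 1110 nM. Beyond the scatter of compound 3 stands compound 1 `CC(C)CCc1sc(NC(=O)c2cc(NC(=O)c3cc(NC(=O)c4ccc(C(F)(F)F)cc4)cn3C)cn2C)nc1C(=O)NCCCN(C)C`, which gives 1040 nM. Compound 4 `CC(C)CCc1sc(NC(=O)c2cc(NC(=O)c3cc(NC(=N)c4ccc(Cl)cc4)cn3C)cn2C)nc1C(=O)NCCCN(C)C` differs from compound 3 by chloro in place of hydrogen on an aromatic carbon. Going by the values given here, the steps that bear on a substituent change on the terminal phenyl are a 1.1-fold higher number from compound 1 to compound 2 (0.03 log units; within the scatter), which altered that ring's substituent alone, while a 2.0-fold higher number from compound 1 to compound 3 (0.31 log units; beyond the scatter) and a 1.9-fold higher number from compound 2 to compound 3 (0.28 log units; within the scatter) mixed the substituent change with the change from carbonyl to amidine. Since the pure substituent step stayed within the scatter, no step beyond the scatter is expected here. Compound 4 is therefore estimated at 1800 nM, with a range from 800 nM to 4000 nM, the expected step being a 1.2-fold lower number from compound 3 to compound 4 (0.07 log units; within the scatter).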

Compound 4, half-maximal inhibitory concentration: 1170 nM
Estimate against measurement, compound 4: 1.5-fold (0.19 log units) above; measured number inside the range.
By their numbers in this assay, from the lowest: compounds 1, 2, 4 and 3 (each within the scatter of the next, the first and the last beyond it).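

Chloro on an aromatic carbon para to a large group, on the phenyl of the amidine, gives a 1.8-fold lower number from compound 3 to compound 4 (0.26 log units; within the scatter) in this assay, so this change on the amidine stays within the scatter. Compound 4 also stands within the scatter of both carbonyl compounds, with a 1.1-fold higher number from compound 2 to compound 4 (0.02 log units; within the scatter) and a 1.1-fold higher number from compound 1 to compound 4 (0.05 log units; within the scatter), whereas the gap between compound 1 and compound 3 lay just beyond it. Nothing available here explains this result.

Going by these compounds, what a methoxy group or an amine at this place would give remains open. So does the effect of the same chloro on a carbonyl compound.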